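Replacing 1-phenylbutyl with 2-methoxybenzyl on a shared core

The source may report more compounds than this note shows. Statements on the series, on what has been measured and on what is new or still open speak of the compounds shown alone.

Measured so far in a functional assay (plasma) with Oryctolagus cuniculus as the target; a lower number here means a stronger inhibitor, a higher number a weaker inhibitor:
- compound 1 `Cc1nc2cnccc2n1CC1CCN(C(=O)CNC(c2ccccc2)c2ccccc2)CC1`: 13 nM
- compound 2 `COC(=O)NC(CC(=O)N1CCC(Cn2c(C)nc3cnccc32)CC1)c1ccccc1`: 12 nM
- compound 3 `CCCC(CC(=O)N1CCC(Cn2c(C)nc3cnccc32)CC1)c1ccccc1`: 11 nM

All three numbers lie within the usual scatter of one another, so compound 3 at 11 nM cannot be separated from compound 1 or compound 2 in this assay. The next compound, compound 4 `COc1ccccc1CCC(=O)N1CCC(Cn2c(C)nc3cnccc32)CC1`, keeps the core of compound 3 and changes one group: 2-methoxybenzyl in place of 1-phenylbutyl on a saturated chain carbon bound to a carbonyl carbon. In words, 2-methoxybenzyl stands in place of 1-phenylbutyl on a saturated chain carbon bound to a carbonyl carbon.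

Going by the values given here, only one measured step bears on this change. It is a 1.1-fold lower number from compound 2 to compound 3 (0.04 log units; within the scatter), which put propyl in place of (methoxycarbonyl)amino and stayed within the scatter. That step shows that one substituent change on this chain left the number unchanged within the scatter, but it is only a partial guide. Among the compounds with values here, no measured compound carries 2-methoxybenzyl, and none shows what happens when the whole 1-phenylbutyl group is replaced.

On the evidence of a 1.1-fold lower number from compound 2 to compound 3 (0.04 log units; within the scatter), no step beyond the scatter is expected, with a wide margin kept for the untested group. The expected step is a 1.6-fold higher number from compound 3 to compound 4 (0.21 log units; within the scatter). For compound 4 the estimated value is 18 nM, with an expected range from 6 nM to 55 nM.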

Compound 4, half-maximal inhibitory concentration: 15 nM
For compound 4 the middle estimate is 1.2-fold (0.08 log units) above the measured one; the range from low to high includes it.
By their numbers in this assay, from the lowest: compounds 3, 2, 1 and 4 (each within the scatter of the next).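

In this assay, the step with the whole 1-phenylbutyl group replaced by 2-methoxybenzyl on the saturated chain carbon bound to a carbonyl carbon is a 1.4-fold higher number from compound 3 to compound 4 (0.13 log units; within the scatter). The earlier step changed only one substituent on this chain, whereas this one shows that the number also stays within the scatter when the group is exchanged as a whole, including the group's saturated chain branch. The exchange adds an oxygen and a hydrogen-bond acceptor and gives up one heavy atom, and the six-membered aromatic ring of carbon remains in both groups, but nothing in the data given bears on the reason for this outcome.

Since both exchanges at this place stay within the scatter, the compounds shown do not reveal any group here that moves the number, and they cannot separate the part played by the methoxy from that of the rest of 2-methoxybenzyl. On these data alone, it remains open whether plain benzyl, a group carrying a carboxylic acid or an amine, or a longer chain in this place would take the number beyond the scatter.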